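From Bromo to Methoxy: Compound 3 to Compound 4

The source may hold more compounds than are shown below. What is called first, only, known or untested is meant among the compounds shown, and "the series" means these compounds.

Three measured compounds share one core and differ only in a single group on one aromatic ring. In a functional assay on MCF7 cells (Homo sapiens) for inhibition, read by MTT assay (a lower number here means a stronger inhibitor, a higher number a weaker inhibitor), compound 1 `COc1ccc(C(Nc2ccc([N+](=O)[O-])cc2)n2c(=O)ccc3cc(O)ccc32)cc1` gives 21100 nM. Compound 2 `COc1ccc(C(Nc2ccc(Cl)cc2)n2c(=O)ccc3cc(O)ccc32)cc1` gives 11300 nM in this assay, and compound 3 `COc1ccc(C(Nc2ccc(Br)cc2)n2c(=O)ccc3cc(O)ccc32)cc1` gives 10800 nM. The step of a 1.9-fold lower number from compound 1 to compound 2 (0.27 log units; within the scatter) and the step of a 2.0-fold lower number from compound 1 to compound 3 (0.29 log units; within the scatter) both fall within the scatter, as does a 1.0-fold lower number from compound 2 to compound 3 (0.02 log units; within the scatter). Compound 3 thus holds the lowest of the three numbers, but its gaps to compound 2 and to compound 1 lie within the scatter, so no order among the three can be claimed.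

Compound 4 `COc1ccc(NC(c2ccc(OC)cc2)n2c(=O)ccc3cc(O)ccc32)cc1` has not yet been measured. It differs from compound 3 by methoxy in place of bromo on an aromatic carbon. Going by the values given here, no measured step involves a methoxy at this place; the three steps that do bear on it, exchanging nitro, chloro and bromo, all stayed within the scatter. On that basis a change no larger than the scatter is expected in this assay, with neither direction favoured. Compound 4 is therefore estimated at 12000 nM, within 5000 nM to 30000 nM, which corresponds to an expected step of a 1.1-fold higher number from compound 3 to compound 4 (0.05 log units; within the scatter).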

Compound 4, half-maximal inhibitory concentration: 49200 nM
For compound 4 the middle estimate is 4.1-fold (0.61 log units) below the measured one; measured number above the stated range.
By their numbers in this assay, from the lowest: compounds 3, 2 and 1 (each within the scatter of the next); then compound 4.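

In this assay, this place on the ring had shown no step beyond the scatter while it carried nitro, chloro or bromo, but methoxy now gives a 4.6-fold higher number from compound 3 to compound 4 (0.66 log units; beyond the scatter), a 4.4-fold higher number from compound 2 to compound 4 (0.64 log units; beyond the scatter) and a 2.3-fold higher number from compound 1 to compound 4 (0.37 log units; beyond the scatter). The number in this assay therefore does depend on the group at this place: all three steps to methoxy run in the same direction and lie beyond the scatter, which sets compound 4 apart from compounds 1, 2 and 3, which remain within the scatter of one another. Nothing available explains why this exchange raises the number when the exchanges among the other three groups did not.

The compounds shown leave open whether the higher number belongs to methoxy alone or would also appear with a hydroxyl, an amine or a longer ether such as ethoxy at this place. They also leave open whether the methoxy on the other aromatic ring, which all four compounds share, influences the size of these steps, and how a group such as a halogen would behave there.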